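Working notes: exchanging the ring on sulfur in compound 3

A few compounds are considered here, and "the series" means these few. Any claim that something is new, unique, unknown or untested is made for them only; others in the source may bear on it.

compound 1 `COc1ccc(CN(C(=O)Cn2cc(COc3ccc4ccc(=O)oc4c3)nn2)c2cc(OC)c(OC)c(OC)c2)cc1`: 180 nM
compound 2 `COc1ccc(CN(C(=O)Cn2cc(COc3ccccc3)nn2)c2cc(OC)c(OC)c(OC)c2)cc1`: 12500 nM
compound 3 `COc1ccc(CN(C(=O)Cn2cc(CSC3=NCCS3)nn2)c2cc(OC)c(OC)c(OC)c2)cc1`: 1610 nM

All three values come from a functional assay on MGC-803 cells (Homo sapiens) for antiproliferative activity, read by MTT assay, with a stated time of 48 h; on this read-out lower numbers stand for stronger inhibition and higher numbers for weaker inhibition. Compound 3 holds the middle of the three numbers, as shown by a 7.8-fold lower number from compound 2 to compound 3 (0.89 log units; beyond the scatter) and an 8.9-fold higher number from compound 1 to compound 3 (0.95 log units; beyond the scatter). The next change is a group of 6 heavy atoms (2 carbon, 4 nitrogen; one five-membered aromatic ring with 4 hetero atoms) in place of a group of 5 heavy atoms (3 carbon, 1 nitrogen, 1 sulfur; one five-membered non-aromatic ring with 2 hetero atoms), on a sulfur, which gives compound 4 `COc1ccc(CN(C(=O)Cn2cc(CSc3nnnn3C)nn2)c2cc(OC)c(OC)c(OC)c2)cc1`. Within the data shown here, no measured step makes this exact exchange. The nearest evidence is the other group exchanges in the series, namely those two modest steps and the large 69-fold higher number from compound 1 to compound 2 (1.84 log units; beyond the scatter). They show that such exchanges can move the number, but not the direction for a 1-methyl-1H-tetrazol-5-yl group. A modest rise in this assay is therefore expected, though a fall is not excluded. The estimated value for compound 4 is 3000 nM, with an expected range of 700 nM to 12000 nM. The expected change is a 1.9-fold higher number from compound 3 to compound 4 (0.27 log units; within the scatter).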

Compound 4, half-maximal inhibitory concentration: 6570 nM
The estimate for compound 4 lay 2.2-fold (0.34 log units) below the measured number, within the range that was stated.
By their numbers in this assay, from the lowest: compound 1; then compound 3; then compounds 4 and 2 (each within the scatter of the next).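

In this assay, 1-methyl-1H-tetrazol-5-yl on this sulfur is a poorer exchange than the non-aromatic ring it replaces (a 4.1-fold higher number from compound 3 to compound 4 (0.61 log units; beyond the scatter)), so the position distinguishes between two five-membered rings of similar size. The (1-methyl-1H-tetrazol-5-yl)sulfanyl group cannot be separated from the phenoxy group (a 1.9-fold lower number from compound 2 to compound 4 (0.28 log units; within the scatter)), and the group in compound 1 remains far better than either (a 37-fold higher number from compound 1 to compound 4 (1.56 log units; beyond the scatter)). Nothing available explains these steps. Still open, from the compounds shown here alone, is how a simple amine, a carboxylic acid or a longer alkyl chain on this sulfur would read.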